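The source may report more compounds than this note shows. Statements on the series, on what has been measured and on what is new or still open speak of the compounds shown alone.

For the measured compounds named here, in an ADME assay on A549 cells (Homo sapiens) for cytotoxicity, read by resazurin assay, with a stated time of 48 h (on this read-out lower numbers stand for higher toxicity in this test and higher numbers for lower toxicity in this test), compound 1 (`CCNc1ccc(NC(=O)c2cc(Cl)ccc2O)c(Cl)c1`) gives 30200 nM, while compound 2 (`O=C(Nc1ccc(NCc2cccc(Br)n2)cc1Cl)c1cc(Cl)ccc1O`) gives 92300 nM, the higher of the two numbers measured so far. Compound 3 (`O=C(Nc1ccc(N(CCCO)CCCO)cc1Cl)c1cc(Cl)ccc1O`) keeps the shared core and differs from compound 2 in a single place: bis(3-hydroxypropyl)amino in place of ((6-bromopyridin-2-yl)methyl)amino on an aromatic carbon. Going by the values given here, only one measured step bears on this change, namely a 3.1-fold higher number from compound 1 to compound 2 (0.49 log units; beyond the scatter). That modest step introduced the same bromopyridine ring that compound 3 now lacks, so it offers a rough guide. Like compound 1, compound 3 has no ring in this group, but its two hydroxypropyl chains have no measured counterpart, and the data cannot show what they contribute. In this assay, a step towards a lower number is therefore expected, no larger than the modest one seen between the two measured compounds and possibly none beyond the scatter. The estimated step is a 1.5-fold lower number from compound 2 to compound 3 (0.19 log units; within the scatter). For compound 3 the expected value is 60000 nM, with an estimated range of 22000 nM to 150000 nM.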

Compound 3, half-maximal cytotoxic concentration: 114000 nM
The estimate for compound 3 lay 1.9-fold (0.28 log units) below the measured number; low and high end bracket the measured number.
By their numbers in this assay, from the lowest: compound 1; then compounds 2 and 3 (each within the scatter of the next).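

In this assay, the exchange of ((6-bromopyridin-2-yl)methyl)amino for bis(3-hydroxypropyl)amino gives a 1.2-fold higher number from compound 2 to compound 3 (0.09 log units; within the scatter) and so leaves the read-out within the scatter, which shows that the bromopyridine ring is not required for the number seen with compound 2. This position therefore accepts two very different groups of equal heavy-atom count, one with an aromatic ring and one with no ring and more hydrogen-bond donors and acceptors, without a separation in this test. The comparison with the ethylamino group gives a 3.8-fold higher number from compound 1 to compound 3 (0.58 log units; beyond the scatter) as a modest step beyond the scatter, so the earlier step away from compound 1 is not tied to the bromopyridine ring and is matched by a group with no ring at all.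

On these data alone, it remains open whether the terminal hydroxyl groups of compound 3 contribute anything, which a dipropylamino group or a single 3-hydroxypropylamino group at this position would help to settle, and whether a carboxylic acid or a basic amine at the chain ends would keep the number in the same range. Nothing measured here offers an explanation for these numbers.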